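Aryl swap at the shared core: dichlorophenyl for fluorophenyl

The source may report more compounds than this note shows. Statements on the series, on what has been measured and on what is new or still open speak of the compounds shown alone.

Of the compounds shown here, two carry numbers so far. Compound 1 `COc1ccc(-c2c(O)nc3cc(Cl)c([N+](=O)[O-])cc3c2OCCC2CCCCN2)cc1OC` gives 600 nM in a functional assay on cells (Pituitary gland cell) for antagonist activity at Gonadotropin-releasing hormone receptor (Rattus norvegicus); a lower number here means a stronger inhibitor, a higher number a weaker inhibitor. For the measured compounds named here, compound 2 `O=[N+]([O-])c1cc2c(OCCC3CCCCN3)c(-c3cccc(F)c3)c(O)nc2cc1Cl` gives 53 nM in this assay, the lowest of the two numbers, with compound 1 the only neighbour. Going by the values given here, the single step available, an 11-fold lower number from compound 1 to compound 2 (1.05 log units; beyond the scatter), is a large one and comes from the aryl group on the shared core.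

Compound 3 `O=[N+]([O-])c1cc2c(OCCC3CCCCN3)c(-c3cc(Cl)cc(Cl)c3)c(O)nc2cc1Cl` differs from compound 2 at the same position: 3,5-dichlorophenyl in place of 3-fluorophenyl on an aromatic carbon. Among the compounds with values here, no measured pair sets a dichlorophenyl against a fluorophenyl, so the direct size of this change is unknown. Within the data shown here, the step from compound 1 to compound 2 shows only that the aryl group is a sensitive position and that a halogenated phenyl gave the lower number; it does not say how much further a second halogen moves things. The step in this assay is therefore expected to be small, within or near the scatter, with the direction open.

On that basis compound 3 is expected to give 40 nM in this assay, between 15 nM and 150 nM, which would be a step of a 1.3-fold lower number from compound 2 to compound 3 (0.12 log units; within the scatter) and is given as an estimate only.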

Compound 3, half-maximal inhibitory concentration: 24 nM
The estimate for compound 3 lay 1.7-fold (0.22 log units) above the measured number, and the stated range covers the measured number.
By their numbers in this assay, from the lowest: compound 3; then compound 2; then compound 1.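

In this assay, the aromatic carbon that carries the aryl group still has room to move after the 3-fluorophenyl group, with a 2.2-fold lower number from compound 2 to compound 3 (0.34 log units; beyond the scatter), a modest step that lies beyond the scatter. Measured against the 3,4-dimethoxyphenyl group, the 3,5-dichlorophenyl group gives a 25-fold lower number from compound 1 to compound 3 (1.40 log units; beyond the scatter), so both halogenated phenyl groups sit well on the low side of the dimethoxy compound, and compound 3 now has the lowest number of the three, with its steps to the other two printed as beyond the scatter. The step from the 3-fluorophenyl group to the 3,5-dichlorophenyl group changes both the halogen and the number of halogens at once, and no measurement on these compounds accounts for the order of the three aryl groups.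

The compounds shown leave open whether the lower number follows the chlorine, the second halogen or the placement of the halogens in the 3,5-dichlorophenyl group, which a 3-chlorophenyl or a 3,5-difluorophenyl group on the same core would help to separate. They also leave open where an unsubstituted phenyl group would fall, and whether the same order holds once the 2-(piperidin-2-yl)ethoxy group is replaced by a longer chain.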